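A Larger Aryl Group on the Sulfonyl Sulfur

A few compounds are considered here, and "the series" means these few. Any claim that something is new, unique, unknown or untested is made for them only; others in the source may bear on it.

Two related sulfonamides have been measured so far in a functional assay on LOX IMVI cells (Homo sapiens) for cytotoxicity, read by MTT assay, with a stated time of 24 h; a lower number here means a stronger inhibitor, a higher number a weaker inhibitor. There, compound 1 (`COc1cc(-c2nc(-c3ccccc3)[nH]c2-c2ccnc(NCCCNS(=O)(=O)c3ccc(C(F)(F)F)cc3)n2)ccc1F`) gives 75200 nM. Compound 2 (`COc1cc(-c2nc(-c3ccccc3)[nH]c2-c2ccnc(NCCCNS(=O)(=O)c3ccccc3)n2)ccc1Cl`) gives 7470 nM, the lower of the two numbers by a gap beyond the usual scatter, which makes it the stronger inhibitor of this pair. Compound 3 (`COc1cc(-c2nc(-c3ccccc3)[nH]c2-c2ccnc(NCCCNS(=O)(=O)c3cccc4ccccc34)n2)ccc1Cl`) carries naphthalen-1-yl in place of the phenyl on the sulfonyl sulfur of compound 2: naphthalen-1-yl in place of phenyl on a sulfonyl sulfur. Within the data shown here, no measured pair of compounds differs in one place only, so there is no direct guide to the effect of this swap, and the expectation stays loose. The expected change is a 1.5-fold lower number from compound 2 to compound 3 (0.17 log units; within the scatter), a small move toward a lower number that would stay within the scatter. For compound 3 the estimated value is 5000 nM, with an expected range from 1800 nM to 15000 nM.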

Compound 3, half-maximal inhibitory concentration: 13500 nM
Beside the measured number, compound 3's estimate is 2.7-fold (0.43 log units) below it; the range from low to high includes it.
By their numbers in this assay, from the lowest: compounds 2 and 3 (each within the scatter of the next); then compound 1.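

In this assay, among these compounds, the swap of phenyl for naphthalen-1-yl on the sulfonyl sulfur gives a 1.8-fold higher number from compound 2 to compound 3 (0.26 log units; within the scatter), and this is the first comparison here in which only one place changes. A second aromatic ring can therefore be added on the sulfonyl sulfur without a change in the number that stands clear of the usual scatter, though the larger group brings no measurable gain either. Nothing measured here explains this result.

Compound 1 differs from compound 2 and from compound 3 in more than one place, so what the trifluoromethyl on its aryl group contributes remains unsettled. As far as these compounds go, it also stays open whether the number would hold with a non-aromatic group on the sulfonyl sulfur, such as methyl or cyclohexyl, or with a phenyl carrying an amine.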